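Working notes: amide side chain step to compound 3

This account rests on a few compounds, and the source may have more. Where it says the series, first, only, none or still open, it means among the compounds named here.

- compound 1 `CCn1c(C(=O)NCCO)ccc1C(CC)(CC)c1ccc(OCS(=O)(=O)c2ccccc2)c(C)c1`: 19900 nM
- compound 2 `CCn1c(C(=O)N[C@H](CO)CCO)ccc1C(CC)(CC)c1ccc(OCS(=O)(=O)c2ccccc2)c(C)c1`: 15900 nM

In a functional assay on BXPC-3 cells (Homo sapiens) for antiproliferative activity, read by MTT assay, with a stated time of 24 h (on this read-out higher numbers stand for weaker inhibition and lower numbers for stronger inhibition), compound 2 gives 15900 nM and stands within the scatter of compound 1, so the two cannot be ranked.

The next structure is compound 3 `CCn1c(C(=O)N[C@@H](CO)CCCO)ccc1C(CC)(CC)c1ccc(OCS(=O)(=O)c2ccccc2)c(C)c1`. The change to it is a group of 7 heavy atoms (5 carbon, 2 oxygen; no ring) in place of a group of 6 heavy atoms (4 carbon, 2 oxygen; no ring), on an amide-type nitrogen. The group that leaves is 3-hydroxy-1-(hydroxymethyl)propyl, and the shared core stays as it is.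

Among the compounds with values here, one measured step bears on this change: a 1.3-fold lower number from compound 1 to compound 2 (0.10 log units; within the scatter). That step puts 2-hydroxyethyl in place of hydrogen on a saturated chain carbon bound to an amide-type nitrogen, so it also alters the group on that nitrogen. Within the data shown here, it stayed within the scatter, although a single step is thin support, and no measured pair yet isolates the present change.

No step beyond the scatter is therefore expected in this assay, and no firm direction can be given for the estimated 1.0-fold higher number from compound 2 to compound 3 (0.00 log units; within the scatter). For compound 3 the estimated value is 16000 nM, with an expected range from 8000 nM to 32000 nM.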

Compound 3, half-maximal inhibitory concentration: 16400 nM
Estimate against measurement, compound 3: 1.0-fold (0.01 log units) below, and the stated range covers the measured number.
By their numbers in this assay, from the lowest: compounds 2, 3 and 1 (each within the scatter of the next).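

In this assay, within the data shown here, the group on the amide-type nitrogen gains one carbon with a 1.0-fold higher number from compound 2 to compound 3 (0.01 log units; within the scatter) while the counts of hydrogen-bond donors and acceptors stay the same, and this is the first measured pair in which the entering and leaving groups both carry a defined stereocentre. Measured against the simpler side chain of compound 1, 3-hydroxypropyl in place of hydrogen gives a 1.2-fold lower number from compound 1 to compound 3 (0.08 log units; within the scatter) and joins the earlier 2-hydroxyethyl step inside the scatter, so at this position neither branched group separates from compound 1 and the two branched groups do not separate from each other. No measured evidence is at hand that would account for these small steps.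

All three side chains shown are saturated, carry hydroxyl groups and contain no ring, so it remains open whether an amine, a carboxylic acid or a longer chain on the amide-type nitrogen would give a step beyond the scatter. Also open is what the opposite configuration at the defined stereocentre of compound 2 or compound 3 would give, since no pair shown isolates that feature.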